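This account rests on a few compounds, and the source may have more. Where it says the series, first, only, none or still open, it means among the compounds named here.

Of the compounds shown here, two with the same long-chain amide core have so far been tested in a functional assay on A-431 cells (Homo sapiens) for cytotoxicity, read by MTT assay, with a stated time of 48 h; on this read-out higher numbers stand for weaker inhibition and lower numbers for stronger inhibition. Compound 1 `CCCCCCCCCCCCNC(=O)[C@@H](NC(=O)c1nccc2ccccc12)[C@@H](C)O` carries an isoquinolin-1-yl group on the carbonyl carbon of its second amide, and in this assay compound 1 gives 62800 nM. Compound 2 `CCCCCCCCCCCCNC(=O)[C@@H](NC(=O)c1cc2ccccc2[nH]1)[C@@H](C)O` carries a 1H-indol-2-yl group in that place instead, and in this assay compound 2 gives 10300 nM. Among the compounds with values here, that single swap produced a 6.1-fold lower number from compound 1 to compound 2 (0.79 log units; beyond the scatter), so compound 2 has the lowest number of the two measured compounds, with compound 1 as its only neighbour.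

Compound 3 `CCCCCCCCCCCCNC(=O)[C@@H](NC(=O)/C=C/c1ccccc1)[C@@H](C)O` follows from compound 2 by a change at the same carbonyl carbon: 2-phenylethenyl in place of 1H-indol-2-yl on a carbonyl carbon. Within the data shown here, only one measured step bears on this position, the one from compound 1 to compound 2, and it shows that the number there is sensitive to which group sits on that carbonyl carbon, moving beyond the usual scatter. Compound 3 loses the hydrogen-bond donor and the five-membered aromatic ring that distinguish compound 2 from compound 1, so a step back toward a higher number is expected in this assay, roughly a 2.9-fold higher number from compound 2 to compound 3 (0.46 log units; beyond the scatter). Compound 3 is therefore estimated at 30000 nM, within a range from 8000 nM to 120000 nM.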

Compound 3, half-maximal inhibitory concentration: > 200000 nM
Compound 3: no number, only a limit (the forecaster's own chance of this, stated with the estimate: 15%); at least 6.6-fold (0.82 log units) between middle value and limit.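

Compound 3 gives no number in this assay, only a limit: the limit of > 200000 nM in this assay, at which 1 of the 3 values shown sits. On the carbonyl carbon, 2-phenylethenyl gives an at least 19-fold higher number from compound 2 to compound 3 (1.28 log units; beyond the scatter) and an at least 3.1-fold higher number from compound 1 to compound 3 (0.50 log units; beyond the scatter) in the same assay, so it ranks behind both groups tested before it, not just behind the better one. Within the data shown here, the earlier step showed only that two groups with two fused rings differ at this place, whereas this result shows that the choice of group can take the number from a measured value to a limit, and that the true gap could be wider than these steps state.

The change from compound 2 to compound 3 removes the five-membered aromatic ring and its nitrogen and adds a double bond outside the ring, all at once, so the compounds shown cannot tell which of these differences matters, and a plain phenyl group on the carbonyl carbon would be the simplest way to separate them. From the compounds shown here alone, it also stays open whether an amine or a carboxylic acid on the indole ring of compound 2 would move the number further, or how a shorter chain in place of the long one would act with any of these groups.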